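This account rests on a few compounds, and the source may have more. Where it says the series, first, only, none or still open, it means among the compounds named here.

In an ADME assay on Huh-7 cells (Homo sapiens) for cytotoxicity, read by MTT assay, with a stated time of 48 h (on this read-out higher numbers stand for lower toxicity in this test and lower numbers for higher toxicity in this test), the measured compounds stand as follows: compound 1 `CN(C)CCCCOC(=O)Nc1ccc(Cn2nc(-c3ccccc3)c3ccccc3c2=O)cc1` gives 16000 nM; compound 2 `COc1ccc(-c2nn(Cc3ccc(NC(=O)OCCCCN(C)C)cc3)c(=O)c3ccccc23)cc1` gives 20300 nM; compound 3 `CN(C)CCCCOC(=O)Nc1ccc(Cn2nc(-c3ccc(C(F)(F)F)cc3)c3ccccc3c2=O)cc1` gives 3360 nM.

Compound 3 holds the lowest of the three numbers in this assay: a 4.8-fold lower number from compound 1 to compound 3 (0.68 log units; beyond the scatter) and a 6.0-fold lower number from compound 2 to compound 3 (0.78 log units; beyond the scatter), whereas a 1.3-fold higher number from compound 1 to compound 2 (0.10 log units; within the scatter). Compound 4 `CN(C)CCCCOC(=O)Nc1ccc(Cn2nc(-c3cccc(F)c3)c3ccccc3c2=O)cc1` differs from compound 3 in one place: 3-fluorophenyl in place of 4-(trifluoromethyl)phenyl on an aromatic carbon. Going by the values given here, the steps that bear on this are the two that brought in trifluoromethyl, and both lowered the number modestly. Taking trifluoromethyl away again is therefore expected to move the number in this assay back toward that of compound 1; the single fluorine that enters has no measured counterpart among these compounds. Compound 4 is therefore estimated at 11000 nM, within 4000 nM to 30000 nM, which would mean an expected 3.3-fold higher number from compound 3 to compound 4 (0.52 log units; beyond the scatter).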

Compound 4, half-maximal cytotoxic concentration: 37400 nM
Compound 4: the middle estimate sits 3.4-fold (0.53 log units) below what was measured; measured number above the stated range.
By their numbers in this assay, from the lowest: compound 3; then compounds 1, 2 and 4 (each within the scatter of the next, the first and the last beyond it).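

In this assay a single fluoro on the phenyl ring does not lower the number as trifluoromethyl did: a 2.3-fold higher number from compound 1 to compound 4 (0.37 log units; beyond the scatter) is a modest rise for fluoro in place of hydrogen. The exchange of 4-(trifluoromethyl)phenyl for 3-fluorophenyl gives an 11-fold higher number from compound 3 to compound 4 (1.05 log units; beyond the scatter) and is the largest step in the series, while a 1.8-fold higher number from compound 2 to compound 4 (0.27 log units; within the scatter) leaves 3-fluorophenyl and 4-methoxyphenyl within the scatter of each other. Nothing available explains these steps. The compounds shown leave open whether this rise follows the fluorine itself or its place on the phenyl ring, and how a chlorine or an amine there would read.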